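This account rests on a few compounds, and the source may have more. Where it says the series, first, only, none or still open, it means among the compounds named here.

Compound 1, with the structure `CC(=O)SCCCCCCNC(=O)c1cc(-c2ccncc2)n[nH]1`, is measured in a functional assay on MCF7 cells (Homo sapiens) for inhibition, read by MTT assay, with a stated time of 96 h (on this read-out higher numbers stand for weaker inhibition of growth and lower numbers for stronger inhibition of growth), and gives 24900 nM. Compound 2, with the structure `CCCCCCCC/C=C\CCCCCCCC(=O)SCCCCCCNC(=O)c1cc(-c2ccncc2)n[nH]1`, gives 31100 nM in this assay, a gap to compound 1 that lies within the scatter, so the two cannot be placed in order. Compound 3, with the structure `O=C(NCCCCCCS)c1cc(-c2cccc3ccccc23)n[nH]1`, sits at the limit of > 50000 nM in this assay, at which 1 of the 3 values shown sits, in this assay; its entry > 50000 nM is a limit, not a number. Of the two numbers that are numbers, compound 1 holds the lower one.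

Compound 4, with the structure `CCC(=O)SCCCCCCNC(=O)c1cc(-c2ccncc2)n[nH]1`, has not yet been measured in this assay. It differs from compound 1 by methyl in place of hydrogen on a saturated chain carbon bound to a carbonyl carbon. Going by the values given here, with no comparable pair measured, the only guide is that compound 1 and compound 2, whose acyl groups differ widely, still lie within the scatter of each other. The expected step is therefore small, a 1.0-fold lower number from compound 1 to compound 4 (0.02 log units; within the scatter), and in no clear direction. Compound 4 is estimated to give 24000 nM in this assay, in the range 11000 nM to 50000 nM.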

Compound 4, concentration for 50% growth inhibition: > 50000 nM
Compound 4: a limit, no number; the forecaster's own chance of this, stated with the estimate: 15%; middle value at least 2.0-fold (0.31 log units) away from the limit.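

Compound 4 sits at a limit in this assay, and this entry is not a number: the limit of > 50000 nM in this assay, at which 2 of the 4 values shown sit.

Going by these compounds alone, this gives the first comparison at this position in which only one place changes, methyl in place of hydrogen on a saturated chain carbon bound to a carbonyl carbon, with an at least 2.0-fold higher number from compound 1 to compound 4 (0.30 log units; that floor lies within the scatter); that figure is only a floor, so the true size of the step stays unknown. Compound 2, whose acyl group is much longer, gives 31100 nM. Among the compounds shown, a larger acyl group therefore does not by itself lead to a limit.

Going by these compounds, whether the step from acetyl to propanoyl truly lies beyond the scatter remains open. So does the way the read-out responds to other acyl groups of intermediate size, such as butanoyl or octanoyl, or to a ring-bearing one such as benzoyl.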